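The source may report more compounds than this note shows. Statements on the series, on what has been measured and on what is new or still open speak of the compounds shown alone.

Compound 1 `COc1ccc(-c2cc3ccccc3nc2/C=C/C(=O)c2ccc(O)cc2)cc1` carries a 4-hydroxyphenyl on the carbonyl carbon of the shared core. In a functional assay on NCI-H460 cells (Homo sapiens) for antiproliferative activity, read by XTT assay, with a stated time of 72 h (a higher number here means a weaker inhibitor, a lower number a stronger inhibitor), compound 1 gives 6930 nM, the highest of the two numbers recorded there. Compound 2 `COc1ccc(-c2cc3ccccc3nc2/C=C/C(=O)c2ccc(Br)s2)cc1` gives 5170 nM, and the step of a 1.3-fold lower number from compound 1 to compound 2 (0.13 log units; within the scatter) stays within the scatter. For compound 3 `COc1ccc(-c2cc3ccccc3nc2/C=C/C(=O)c2sccc2N)cc1` the assay reports only a limit, > 10000 nM (the limit of > 10000 nM in this assay, at which 1 of the 3 values shown sits). The step of an at least 1.4-fold higher number from compound 1 to compound 3 (0.15 log units; that floor lies within the scatter) is thus a floor, not a number. Compound 4 `COc1ccc(-c2cc3ccccc3nc2/C=C/C(=O)c2cnc(N)nc2C)cc1` differs from compound 1 by 2-amino-4-methylpyrimidin-5-yl in place of 4-hydroxyphenyl on a carbonyl carbon. Both replacements already made at this carbonyl carbon either left the number where it was or pushed it to the limit, so compound 4 is expected to show no step beyond the scatter in this assay, with a weaker result somewhat more likely than a stronger one. Compound 4 is therefore estimated at 8000 nM, within 3500 nM to 20000 nM, a step of a 1.2-fold higher number from compound 1 to compound 4 (0.06 log units; within the scatter).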

Compound 4, half-maximal inhibitory concentration: > 10000 nM
Compound 4: a limit, no number; the forecaster's own chance of this, stated with the estimate: 30%; at least 1.2-fold (0.09 log units) between middle value and limit.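

In this assay compound 4 reaches only a limit, > 10000 nM, so a six-membered ring, 2-amino-4-methylpyrimidin-5-yl, now joins 3-aminothiophen-2-yl at that limit on this carbonyl carbon: the limit of > 10000 nM in this assay, at which 2 of the 4 values shown sit.

The replacement of 4-hydroxyphenyl gives an at least 1.4-fold higher number from compound 1 to compound 4 (0.15 log units; that floor lies within the scatter), and the replacement of 5-bromothiophen-2-yl gives an at least 1.9-fold higher number from compound 2 to compound 4 (0.28 log units; that floor lies within the scatter), so neither step is shown to exceed the scatter; the step from compound 3 to compound 4 cannot be read. Both groups at the limit carry an amino group, while the two without one give numbers.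

Going by these compounds, how far past the limit compound 3 and compound 4 lie stays open. So does what a plain phenyl or a pyrimidin-5-yl without the amine would give at this carbonyl carbon.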